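Replacing the Furanylmethyl Amide of Compound 3 with a Methyl Ester

This account rests on a few compounds, and the source may have more. Where it says the series, first, only, none or still open, it means among the compounds named here.

Three compounds share one core, each carrying the same bromine and the same diamino cyclohexyl substituent, and differ only in what hangs from the carbonyl carbon. Compound 1 `COc1cccc(CNC(=O)c2nc(Br)c3cccnc3c2N[C@H]2CC[C@H](N)CC2)c1` was not given a result in a functional assay on MCF7 cells (Homo sapiens) for cytotoxicity, read by MTT assay, with a stated time of 72 h; a higher number here means a weaker inhibitor, a lower number a stronger inhibitor; for compound 1 the entry in this assay reads "not determined" (no result reported). Compound 2 `N[C@H]1CC[C@H](Nc2c(C(=O)NCc3ccccn3)nc(Br)c3cccnc23)CC1` was tested there, and in this assay compound 2 gives 15000 nM. Compound 3 `N[C@H]1CC[C@H](Nc2c(C(=O)NCc3ccco3)nc(Br)c3cccnc23)CC1`, whose amide bears a ((furan-2-yl)methyl)amino group, also has no reported result in this assay, where the entry for compound 3 reads "not determined" (no result reported); so compound 3 stands without a single number, as does compound 1, and only compound 2 carries a measurement in this series.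

Compound 4 `COC(=O)c1nc(Br)c2cccnc2c1N[C@H]1CC[C@H](N)CC1` is obtained from compound 3 by the change methoxy in place of ((furan-2-yl)methyl)amino on a carbonyl carbon: a methoxycarbonyl group replaces the ((furan-2-yl)methyl)carbamoyl group on the carbonyl carbon whose other neighbour is an aromatic carbon. Going by the values given here, no step between measured compounds is recorded for this change, and compound 3 itself has no number to anchor it. Among the compounds with values here, since the only measured compound, compound 2, shows 15000 nM in this assay, compound 4 is expected to remain weak, with a value no better than that and possibly beyond the scatter toward weaker. Compound 4 is estimated to give 25000 nM in this assay, within a range of 6000 nM to 100000 nM.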

Compound 4, half-maximal inhibitory concentration: > 20000 nM
Compound 4 was reported as a limit; the forecaster's own chance of this, stated with the estimate: 40%; the middle value lies beyond the limit too.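

Compound 4 enters the series only as a limit of the assay, in this assay: the limit of > 20000 nM in this assay, at which 1 of the 4 values shown sits. Exchanging ((pyridin-2-yl)methyl)amino for methoxy on a carbonyl carbon gives an at least 1.3-fold higher number from compound 2 to compound 4 (0.12 log units; that floor lies within the scatter), so this position, now carrying a substituent with no ring, shows no gain in strength, while the limit leaves it unsettled whether any real loss occurred. Steps that start from compound 1 or compound 3 cannot be read, which leaves the change from ((furan-2-yl)methyl)amino to methoxy without a size of its own and leaves compound 2 as the only reference for compound 4.

The compounds shown leave open how far the true value of compound 4 lies past its limit, and whether a carboxylic acid or a simple methylamino group on the same carbonyl carbon would give a readable number in this assay. They also leave open whether a longer chain ending in an amine, set in place of methoxy, would bring the series to a value clearly different from that of compound 2.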